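The source may hold more compounds than are shown below. What is called first, only, known or untested is meant among the compounds shown, and "the series" means these compounds.

Working notes on the series. Compound 1 `Fc1ccccc1Cn1nnc2c(Br)cccc21` and compound 2 `Clc1ccc(Cn2nnc3c(Br)cccc32)cc1` share the same core and differ in two places on the benzyl ring, so no single-change step can be read between them. In a functional assay on cells for positive allosteric modulation of metabotropic glutamate receptor 2 (Homo sapiens), read by fluorescence and calcium flux, with a stated time of 30 min (on this read-out lower numbers stand for an effect already at smaller amounts and higher numbers for an effect only at larger amounts of compound), compound 1 gives 64 nM. In this assay, going by the values given here, compound 2 gives 17 nM, the lowest of the two numbers measured so far; the gap to compound 1 is beyond the usual scatter of repeated measurements.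

Compound 3 `Fc1cc(Cl)ccc1Cn1nnc2c(Br)cccc21` is the next member and differs from compound 2 by fluoro in place of hydrogen on an aromatic carbon. Among the compounds with values here, no step between two measured compounds that differ in only one place exists, so the effect of adding a fluoro at this position cannot be read from measured data. The step of a 1.3-fold higher number from compound 2 to compound 3 (0.11 log units; within the scatter) is expected to be small, and a result that stays within the scatter of compound 2 is the most likely outcome in either direction. For compound 3 the estimate in this assay is 22 nM, with a range from 8 nM to 60 nM; a reported limit rather than a number is considered unlikely.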

Compound 3, half-maximal effective concentration: 23 nM
For compound 3 the middle estimate is 1.0-fold (0.02 log units) below the measured one, within the range that was stated.
By their numbers in this assay, from the lowest: compounds 2 and 3 (each within the scatter of the next); then compound 1.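

In this assay, fluoro in place of hydrogen on an aromatic carbon, ortho to a large group and meta to a chloro group, gives a 1.4-fold higher number from compound 2 to compound 3 (0.13 log units; within the scatter) and so leaves the read-out within the scatter on this background. The series now also holds a second single-place step: a chloro group entering on the benzyl ring gives a 2.8-fold lower number from compound 1 to compound 3 (0.44 log units; beyond the scatter) and so, with the fluoro present, goes with a lower number beyond the scatter. Of the two groups on the benzyl ring of compound 3, the chloro is thus the one whose presence separates the numbers, though this rests on a single comparison for each group. No measurement at hand gives a reason for either step.

From the compounds shown here alone, whether fluoro at this carbon would also stay within the scatter on a benzyl ring without the chloro group remains open. Also open, going by these compounds, is how a group other than fluoro at this carbon, such as methoxy or an amine, would compare with compound 3, and whether a methyl or a nitrile could stand in place of the chloro.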